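Primary amine in place of a tertiary one on the chain

A few compounds are considered here, and "the series" means these few. Any claim that something is new, unique, unknown or untested is made for them only; others in the source may bear on it.

The study covers four compounds built on a shared core with a fluorinated benzylic amide. Compound 1 `O=C(NCc1ccc(F)cc1)c1nc(NCCO)c2cccnc2c1O` carries a short hydroxyethylamino arm and a hydroxy group on the core, but in a functional assay on HCT-116 cells (Homo sapiens) for cytotoxicity, read by MTT assay, with a stated time of 72 h (on this read-out lower numbers stand for stronger inhibition and higher numbers for weaker inhibition), compound 1 has no result, recorded as "not determined" (no result reported). Compound 3 `CS(=O)(=O)NCCCCCCN(c1nc(C(=O)NCc2ccc(F)cc2)c(O)c2ncccc12)S(C)(=O)=O` bears a long chain ending in a methanesulfonamide and gives 4000 nM in this assay. Compound 2 `CN(C)CCCNc1c(C(=O)NCc2ccc(F)cc2)nc(Br)c2cccnc12` reaches only a limit of this assay, reported as > 10000 nM. Among the values shown, compound 2 therefore stands at the limit (the limit of > 10000 nM in this assay, at which 1 of the 3 values shown sits), the single entry of the three without a number of its own, while compound 3 alone provides a measured figure.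

Compound 4 `NCCCCCCNc1c(C(=O)NCc2ccc(F)cc2)nc(Br)c2cccnc12` differs from compound 2 in one place: 3-aminopropyl in place of dimethylamino on a saturated chain carbon, three bonds along the chain from a nitrogen on an aromatic ring. For the measured compounds named here, no step between measured compounds is available, so the size of this change cannot be read from a neighbouring pair. Compound 4 is expected to remain near the limit, with an estimate of 8000 nM and a range of 2000 nM to 30000 nM in this assay. The step of an at least 1.2-fold lower number from compound 2 to compound 4 (0.09 log units; that floor lies within the scatter) is expected to be small, not clearly beyond the scatter.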

Compound 4, half-maximal inhibitory concentration: > 10000 nM
Compound 4 was reported as a limit; the forecaster's own chance of this, stated with the estimate: 55%; middle value at least 1.2-fold (0.09 log units) away from the limit.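

In this assay compound 4 gives > 10000 nM, which is a limit of the assay. For the compounds shown here, compound 2 also stands at a limit, and no step between compound 2 and compound 4 can be read. The compounds shown leave open whether 3-aminopropyl in place of dimethylamino changes the result at all.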